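The source may report more compounds than this note shows. Statements on the series, on what has been measured and on what is new or still open speak of the compounds shown alone.

Three compounds sharing one kind of core have been examined in a functional assay on L1210 cells (Mus musculus) for inhibition; on this read-out higher numbers stand for weaker inhibition and lower numbers for stronger inhibition. Compound 1 `O=C1/C(=C/c2ccc(Cl)c(Cl)c2)CCCc2ccccc21` gives 45700 nM. Compound 2 `O=C1/C(=C/c2ccccc2Cl)Cc2ccccc21` gives 152000 nM, and compound 3 `O=C1/C(=C/c2ccccc2F)Cc2ccccc21` gives 150000 nM. Compound 2 thus holds the top number of the three; compound 3 sits within the usual scatter of it, while compound 1, which differs from compound 2 both in its core and in its halogen pattern, shows a number beyond the scatter below it. Within the data shown here, the only single change measured so far is a 1.0-fold lower number from compound 2 to compound 3 (0.01 log units; within the scatter), so exchanging one halogen for another on the same aromatic carbon did not move the read-out noticeably.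

Compound 4 `O=C1/C(=C/c2ccc(Cl)cc2Cl)Cc2ccccc21` differs from compound 2 by chloro in place of hydrogen on an aromatic carbon. Among the measured compounds shown here, no measured step tells what a second chloro does on this core: the step from compound 2 to compound 3 only shows that the identity of the single halogen hardly matters, and compound 1 carries two chlorines on a different core, so its value cannot be carried over. On this basis a shift of a 1.5-fold lower number from compound 2 to compound 4 (0.18 log units; within the scatter) is expected in this assay, small and pointing toward a somewhat lower number. Compound 4 is therefore estimated at 100000 nM, with a range from 40000 nM to 250000 nM.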

Compound 4, half-maximal inhibitory concentration: > 500000 nM
Compound 4: a limit, no number; the forecaster's own chance of this, stated with the estimate: 10%; at least 5.0-fold (0.69 log units) between middle value and limit.
By their numbers in this assay, from the lowest: compound 1; then compounds 3 and 2 (each within the scatter of the next). At a limit, above all of these: compound 4.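

On the shared core, adding a chloro on this aromatic carbon, para to a large group and meta to the chloro group already present in compound 2, moves the read-out in this assay toward weaker inhibition: the result is an at least 3.2-fold higher number from compound 2 to compound 4 (0.51 log units; beyond the scatter). The value of compound 4, > 500000 nM, is a limit of the assay and not a number: the limit of > 500000 nM in this assay, at which 1 of the 4 values shown sits. Among these compounds, the only earlier single change swapped one halogen for another and gave a 1.0-fold lower number from compound 2 to compound 3 (0.01 log units; within the scatter), whereas this step shows that the read-out on this core can move with a change on the aromatic ring, here by the addition of a second halogen.

Going by these compounds, it remains open whether a single chloro on this carbon, without the chloro group of compound 2, would give a similar shift, and whether a second chloro would act the same way on the core of compound 1. Also open, on these data alone, is what a group of another kind on this same aromatic carbon, such as a methoxy group, an amine or a carboxylic acid, would do to the read-out.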